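A few compounds are considered here, and "the series" means these few. Any claim that something is new, unique, unknown or untested is made for them only; others in the source may bear on it.

Values in an ADME assay on HEK293 cells (Homo sapiens) for cytotoxicity, read by resazurin assay, with a stated time of 48 h; a lower number here means that less compound is tolerated, a higher number that more compound is tolerated:
- Compound 1 `Cc1ccc(S(=O)(=O)Nc2ccc(-c3nc4ccccc4o3)cc2)cc1`: 88000 nM.
- Compound 2 `O=S(=O)(Nc1ccc(-c2nc3ccccc3o2)cc1)c1cccc(O)c1`: > 100000 nM, a limit.
- Compound 3 `CCc1ccc(S(=O)(=O)Nc2ccc(-c3nc4ccccc4o3)cc2)cc1`: 82000 nM.

Compound 3 has one numeric neighbour, and the gap is small: a 1.1-fold lower number from compound 1 to compound 3 (0.03 log units; within the scatter). Compound 4 `COc1ccc(S(=O)(=O)Nc2ccc(-c3nc4ccccc4o3)cc2)cc1` carries methoxy in place of ethyl on an aromatic carbon, para to a large group (methoxy in place of ethyl on an aromatic carbon). Among the measured compounds shown here, the closest measured change is the one at this same group, a 1.1-fold lower number from compound 1 to compound 3 (0.03 log units; within the scatter). The steps involving compound 2 are floors only: an at least 1.1-fold higher number from compound 1 to compound 2 (0.05 log units; that floor lies within the scatter) and an at least 1.2-fold lower number from compound 2 to compound 3 (0.08 log units; that floor lies within the scatter). None of these exceeds the scatter, so no step beyond it is expected in this assay. The expected step is a 1.0-fold higher number from compound 3 to compound 4 (0.02 log units; within the scatter). For compound 4 the estimated value is 85000 nM, with an expected range of 50000 nM to 100000 nM.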

Compound 4, half-maximal cytotoxic concentration: > 100000 nM
Compound 4: a limit, no number (the forecaster's own chance of this, stated with the estimate: 30%); middle value at least 1.1-fold (0.07 log units) from the limit.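

At this position, on an aromatic carbon para to a large group, methoxy is the only group shown with a hydrogen-bond acceptor, and in this assay it gives an at least 1.2-fold higher number from compound 3 to compound 4 (0.08 log units; that floor lies within the scatter) and an at least 1.1-fold higher number from compound 1 to compound 4 (0.05 log units; that floor lies within the scatter) as floors only. Going by these compounds, the value of compound 4 is a limit, so the true size of both steps stays unknown.

On these data alone, how an amine or a carboxylic acid at this position would read in this assay remains open. The step from compound 2 to compound 4 cannot be read because both values are limits: the limit of > 100000 nM in this assay, at which 2 of the 4 values shown sit.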